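Trimming the sulfamoyl chain of compound 1

The compounds below may be only part of what the source reports. "The series", "measured", "known", "first", "only" and "open" are said of these compounds alone.

Compound 1, `CCCNS(=O)(=O)c1ccc(Nc2ncc3c(n2)N(C2CCCC2)[C@H](CC)C(=O)N3C)cc1`: 2100 nM
Compound 2, `CCC1C(=O)N(C)c2cnc(Nc3ccc(S(N)(=O)=O)cc3)nc2N1c1ccn(C)n1`: "not active" (no number reported)
Compound 3, `CCC1C(=O)N(C)c2cnc(-n3ccc4cc(C(=O)NC5CCCC5)ccc43)nc2N1c1ccn(C)n1`: "not active" (no number reported)

Among the compounds with values here, in a functional assay on NCI-H1975 cells (Homo sapiens) for antiproliferative activity, read by CCK-8 assay, with a stated time of 72 h (a higher number here means a weaker inhibitor of growth, a lower number a stronger inhibitor of growth), compound 1 gives 2100 nM, and it is the only compound of the three for which a number is reported at all. Compound 2 is reported as "not active" (no number reported) in this assay. Compound 3 is likewise reported as "not active" (no number reported) in this assay. Within the data shown here, compound 1 therefore stands alone as the one reference point with a measured concentration for half-maximal growth inhibition; no step between two measured compounds can be drawn from these data.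

Compound 4, `CC[C@@H]1C(=O)N(C)c2cnc(Nc3ccc(S(=O)(=O)NC)cc3)nc2N1C1CCCC1`, has not been measured yet. It keeps the cyclopentyl substituent and the rest of the core of compound 1 and differs from it only in the sulfonamide chain: hydrogen in place of ethyl on a saturated chain carbon bound to a sulfonamide nitrogen. The change from propylsulfamoyl to methylsulfamoyl is small and lies far from the anilino linkage, so a step of no more than the usual scatter is expected, in no particular direction, with a 1.1-fold lower number from compound 1 to compound 4 (0.02 log units; within the scatter) as the estimated shift.

Compound 4 is thus expected to give about 2000 nM in this assay, within a range of 800 nM to 5000 nM.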

Compound 4, concentration for 50% growth inhibition: 1410 nM
For compound 4 the middle estimate is 1.4-fold (0.15 log units) above the measured one; low and high end bracket the measured number.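

The step gives this position its first reading: in this assay, hydrogen in place of ethyl on a saturated chain carbon bound to a sulfonamide nitrogen gives a 1.5-fold lower number from compound 1 to compound 4 (0.17 log units; within the scatter). The change from propylsulfamoyl to methylsulfamoyl, with the cyclopentyl substituent and the rest of the core held the same, therefore cannot be told from no change in this measurement of growth inhibition, and the propyl chain as a whole is shown not to be needed for the activity of compound 1. The data shown offer no measured property that speaks to why the two compounds read alike.

Compound 2 and compound 3 differ from compound 1 in more than one place, so the steps to them cannot be read, and neither compound says what the cyclopentyl substituent contributes on its own. Going by these compounds, whether the same flat reading would hold for a longer chain such as hexyl, or for a chain ending in an amine or a carboxylic acid on the sulfonamide nitrogen, remains open, since the two compounds compared here span only propyl and methyl.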